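A few compounds are considered here, and "the series" means these few. Any claim that something is new, unique, unknown or untested is made for them only; others in the source may bear on it.

Notes on the series, read in a functional assay, read by spectrophotometry, tested at 100 uM; a lower number here means a stronger inhibitor, a higher number a weaker inhibitor. Compound 1 `O=C(/C=C/c1ccccc1)c1cccc(NC(=O)c2cc(-c3ccncc3)n[nH]2)c1` gives 67100 nM, compound 2 `COc1ccc(/C=C/C(=O)c2cccc(NC(=O)c3cc(-c4ccncc4)n[nH]3)c2)cc1` gives 38400 nM, and compound 3 `COc1cc(/C=C/C(=O)c2cccc(NC(=O)c3cc(-c4ccncc4)n[nH]3)c2)cc(OC)c1OC` gives 54500 nM. Compound 3 cannot be told apart from the other two: a 1.2-fold lower number from compound 1 to compound 3 (0.09 log units; within the scatter), and a 1.4-fold higher number from compound 2 to compound 3 (0.15 log units; within the scatter).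

The next structure is compound 4 `CC(C)c1ccc(/C=C/C(=O)c2cccc(NC(=O)c3cc(-c4ccncc4)n[nH]3)c2)cc1`, which carries 4-isopropylphenyl in place of 3,4,5-trimethoxyphenyl on a double-bonded chain carbon bound to a double-bonded chain carbon. The measured steps that bear on this change are those at the same place, the two above and a 1.7-fold lower number from compound 1 to compound 2 (0.24 log units; within the scatter). All three stay within the scatter across phenyl, 4-methoxyphenyl and 3,4,5-trimethoxyphenyl. The entering group has not been tested, so this evidence is indirect.

No step beyond the scatter is expected in this assay, in either direction, and the estimated step is a 1.2-fold lower number from compound 3 to compound 4 (0.08 log units; within the scatter). For compound 4 the expected value is 45000 nM, with an estimated range from 20000 nM to 100000 nM.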

Compound 4, half-maximal inhibitory concentration: 52300 nM
Compound 4: the middle estimate sits 1.2-fold (0.07 log units) below what was measured, within the range that was stated.
By their numbers in this assay, from the lowest: compounds 2, 4, 3 and 1 (each within the scatter of the next).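

In this assay, the entering 4-isopropylphenyl has only carbon atoms and no hydrogen-bond acceptors, yet the exchange for 3,4,5-trimethoxyphenyl gives a 1.0-fold lower number from compound 3 to compound 4 (0.02 log units; within the scatter), so at this place the oxygen atoms of the methoxy groups are not needed to hold the number at this level. The new group also stays level with the two other members of the set, with isopropyl in place of methoxy on an aromatic carbon giving a 1.4-fold higher number from compound 2 to compound 4 (0.13 log units; within the scatter) and isopropyl in place of hydrogen on an aromatic carbon giving a 1.3-fold lower number from compound 1 to compound 4 (0.11 log units; within the scatter). Nothing on hand accounts for this flat response.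

From the compounds shown here alone, all four compounds share one core and differ only in this aryl group, so the effect of a change elsewhere in the core stays open. Also open, going by these compounds, is whether an amine or a carboxylic acid on this aryl group would produce a step beyond the scatter.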